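The source may hold more compounds than are shown below. What is called first, only, known or untested is meant among the compounds shown, and "the series" means these compounds.

Within the data shown here, in a functional assay on Caco-2 cells (Homo sapiens) for cytotoxicity, read by MTT assay, with a stated time of 48 h (a lower number here means a stronger inhibitor, a higher number a weaker inhibitor), two related compounds have numbers so far. Compound 1 (`COc1cc(/C=C/C2=CC(=O)CC(c3ccc(O)c(OC)c3)N2CCCO)ccc1O`) gives 88000 nM, and compound 2 (`COc1cc(/C=C/C(=O)/C=C(/C=C/c2ccc(O)c(OC)c2)NCCCO)ccc1O`) gives 75700 nM. These two values lie within the usual scatter of repeated measurements, so the data do not separate the pair. Compound 3 (`COCCCNC(=C\C(=O)/C=C/c1ccc(O)c(OC)c1)/C=C/c1ccc(O)c(OC)c1`) has not yet been measured. It differs from compound 2 in one place: methyl in place of hydrogen on an oxygen on a saturated carbon. This is methyl in place of hydrogen on an oxygen on a saturated carbon, so a hydroxy becomes a methoxy. Among the measured compounds shown here, no measured pair shows what this change does here. Resting on compound 2 with 75700 nM, no step beyond the scatter is expected in this assay. The expected step is small, a 1.1-fold lower number from compound 2 to compound 3 (0.03 log units; within the scatter). For compound 3 the estimated value is 70000 nM, with an expected range of 33000 nM to 140000 nM.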

Compound 3, half-maximal inhibitory concentration in the Caco-2 assay: 49100 nM
Compound 3: the middle estimate sits 1.4-fold (0.15 log units) above what was measured; low and high end bracket the measured number.
By their numbers in the Caco-2 assay, from the lowest: compounds 3, 2 and 1 (each within the scatter of the next).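

Among these compounds, this is the first reading of what happens when the hydroxy on the saturated chain becomes a methoxy. In the Caco-2 assay the change gives a 1.5-fold lower number from compound 2 to compound 3 (0.19 log units; within the scatter) and so does not separate the two compounds, which means that adding this methyl has no resolvable effect on the cytotoxicity reading. In a physicochemical assay for solubility, using the shake flask method, in phosphate buffer, with a stated time of 90 min, at pH 6.8 (on this read-out lower numbers stand for lower solubility and higher numbers for higher solubility), compound 2 gives 25400 nM and compound 3 gives 7700 nM. In the physicochemical assay the same change does separate them, with solubility falling: the measured solubility of compound 2, 25400 nM, and of compound 3, 7700 nM, a 3.3-fold lower number (0.52 log units; beyond the scatter).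

Only the methoxy is shown as a replacement, so it remains open whether an amine or a carboxylic acid in place of the hydroxy, or a longer chain carrying it, would move the number in the Caco-2 assay beyond the scatter. From the compounds shown here alone, it also remains open whether the same methyl would lower solubility on the core of compound 1, which carries the same hydroxy.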